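Urea Antagonists: Swapping the Aryl Group on the Pyrazole

The source may report more compounds than this note shows. Statements on the series, on what has been measured and on what is new or still open speak of the compounds shown alone.

Measured compounds:
compound 1, `Cn1ncc2c(NC(=O)NCc3cc(C(C)(C)C)nn3-c3cccc(Cl)c3)cccc21`: 0.4 nM
compound 2, `CC(C)(C)c1cc(CNC(=O)Nc2cccc3[nH]ncc23)n(-c2cccc(F)c2)n1`: 1.3 nM

Both compounds were tested in an assay on CHO-K1 cells for antagonist activity at transient receptor potential cation channel subfamily V member 1 (Homo sapiens), read by FLIPR and calcium flux, with a stated time of 6 min; on this read-out higher numbers stand for weaker inhibition and lower numbers for stronger inhibition. Compound 2 gives 1.3 nM and holds the higher number of the two; compound 1, with 0.4 nM, sits beyond the usual scatter on the lower side. Compound 3, `COc1ccc(-n2nc(C(C)(C)C)cc2CNC(=O)Nc2cccc3[nH]ncc23)cc1`, differs from compound 2 by 4-methoxyphenyl in place of 3-fluorophenyl on an aromatic nitrogen. For the measured compounds named here, no step of this kind has been measured here. Compound 3 is expected to remain close to compound 2 in this assay, with a slight loss of potency, so that a step of a 1.9-fold higher number from compound 2 to compound 3 (0.28 log units; within the scatter) is estimated. The estimated value for compound 3 is 2.5 nM, within a range from 0.5 nM to 12 nM.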

Compound 3, inhibition constant: 62.9 nM
The estimate for compound 3 lay 25-fold (1.40 log units) below the measured number; the whole stated range lies below it.
By their numbers in this assay, from the lowest: compound 1; then compound 2; then compound 3.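

On the aromatic nitrogen, the aryl group proves far from interchangeable: in this assay, 4-methoxyphenyl in place of 3-fluorophenyl brings a 48-fold higher number from compound 2 to compound 3 (1.68 log units; beyond the scatter) and thus a clear loss of potency. Both groups hold a six-membered aromatic ring of carbon only, so the step comes from what that ring carries and where. Nothing available explains why the step is so large. The compounds shown leave open whether the methoxy group itself or its place on the ring matters more, a question that 3-methoxyphenyl and 4-fluorophenyl could separate.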